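The compounds below may be only part of what the source reports. "The series", "measured", "known", "first", "only" and "open" are said of these compounds alone.

In a functional assay on HUVEC cells (Homo sapiens), read by scintillation counting and thymidine incorporation, with a stated time of 24 h (on this read-out higher numbers stand for weaker inhibition and lower numbers for stronger inhibition), three compounds have been measured:

- compound 1 `CCC(C)n1ncn(-c2ccc(N3CCN(c4ccc(OC[C@@H]5CO[C@@](Cc6ccccc6)(c6ccc(Cl)cc6Cl)O5)cc4)CC3)cc2)c1=O`: 513 nM
- compound 2 `CCC(C)n1ncn(-c2ccc(N3CCN(c4ccc(OC[C@@H]5CO[C@@](CN(C)C)(c6ccc(Cl)cc6Cl)O5)cc4)CC3)cc2)c1=O`: 1400 nM
- compound 3 `CCC(C)n1ncn(-c2ccc(N3CCN(c4ccc(OC[C@@H]5CO[C@@](CN6CCNCC6)(c6ccc(Cl)cc6Cl)O5)cc4)CC3)cc2)c1=O`: 608 nM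

Compound 3 stands close to one of the other two, with a 1.2-fold higher number from compound 1 to compound 3 (0.07 log units; within the scatter). The gap to the remaining compound is wider, with a 2.3-fold lower number from compound 2 to compound 3 (0.36 log units; beyond the scatter).

Compound 4 `CCC(C)n1ncn(-c2ccc(N3CCN(c4ccc(OC[C@@H]5CO[C@@](CN6CCN(C)CC6)(c6ccc(Cl)cc6Cl)O5)cc4)CC3)cc2)c1=O` differs from compound 3 by methyl in place of hydrogen on an amine nitrogen in a ring, which turns piperazin-1-yl into 4-methylpiperazin-1-yl. Going by the values given here, no measured step makes this exact change. The closest evidence comes from exchanges of the whole group on the saturated chain carbon, and the largest of these is only modest, at a 2.7-fold higher number from compound 1 to compound 2 (0.44 log units; beyond the scatter). A single added methyl is therefore expected to leave this assay without a step beyond the scatter. The expected change is a 1.2-fold higher number from compound 3 to compound 4 (0.07 log units; within the scatter). For compound 4 the estimated value is 720 nM, with an expected range from 320 nM to 1600 nM.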

Compound 4, half-maximal inhibitory concentration: 396 nM
Compound 4: middle estimate off by 1.8-fold (0.26 log units), on the high side; the range from low to high includes it.
By their numbers in this assay, from the lowest: compounds 4, 1 and 3 (each within the scatter of the next); then compound 2.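

In this assay the amine nitrogen of the piperazin-1-yl ring now has a direct reading, and adding methyl there gives a 1.5-fold lower number from compound 3 to compound 4 (0.19 log units; within the scatter) and so no shift that can be told from repeat measurements. The 4-methylpiperazin-1-yl group keeps the separation from dimethylamino, with a 3.5-fold lower number from compound 2 to compound 4 (0.55 log units; beyond the scatter) as the result of that exchange, while against phenyl it gives a 1.3-fold lower number from compound 1 to compound 4 (0.11 log units; within the scatter) and so stands level with that group. Nothing measured here accounts for any of these steps.

Whether this nitrogen accepts more than a methyl remains open, as neither a longer chain such as ethyl nor an acetyl group appears among the compounds shown. From the compounds shown here alone, it is also open whether a ring with a different second atom, such as morpholin-4-yl, would stay with the piperazin-1-yl compounds or fall nearer to dimethylamino.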